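Aryl-substituted tetracyclic series: cytotoxicity notes toward compound 4

A few compounds are considered here, and "the series" means these few. Any claim that something is new, unique, unknown or untested is made for them only; others in the source may bear on it.

Compound 1 `c1ccc([C@@H]2C[C@@H]3Cc4ccc5ccccc5c4N2O3)cc1`: in an ADME assay on THP-1 cells (Homo sapiens) for cytotoxicity, read by MTT assay, with a stated time of 72 h (on this read-out lower numbers stand for higher toxicity in this test and higher numbers for lower toxicity in this test), compound 1 gives > 350000 nM, which is a limit of the assay rather than a number.
Compound 2 `Clc1ccc([C@@H]2C[C@@H]3Cc4ccc5ccccc5c4N2O3)cc1`: in this assay compound 2 gives > 300000 nM, likewise a limit.
Compound 3 `Brc1ccc([C@@H]2C[C@@H]3Cc4ccc5ccccc5c4N2O3)cc1`: in this assay compound 3 gives > 250000 nM, again a limit.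

Compound 3 thus stands only at a limit in this assay, at the limit of > 250000 nM in this assay, at which 1 of the 3 values shown sits, and the two further values shown are limits as well, at the limit of > 300000 nM in this assay, at which 1 of the 3 values shown sits, and (the limit of > 350000 nM in this assay, at which 1 of the 3 values shown sits). The three steps among the measured compounds, a step that the two limits leave unreadable from compound 1 to compound 2, a step that the two limits leave unreadable from compound 1 to compound 3 and a step that the two limits leave unreadable from compound 2 to compound 3, cannot be read in size, since both ends of each sit at a limit.

Compound 4 `Clc1cccc([C@@H]2C[C@@H]3Cc4ccc5ccccc5c4N2O3)c1` differs from compound 3 by 3-chlorophenyl in place of 4-bromophenyl on a saturated ring carbon. For the measured compounds named here, none of the measured steps bears readably on this change; every halogen-for-hydrogen and halogen-for-halogen step returned limits on both sides. The step that the limit leaves unreadable from compound 3 to compound 4 is therefore expected to be none beyond the scatter, with another limit the most likely report. Compound 4 is expected to give 300000 nM in this assay, with a range from 100000 nM to 400000 nM.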

Compound 4, half-maximal cytotoxic concentration: > 300000 nM
Compound 4: no number, only a limit; the forecaster's own chance of this, stated with the estimate: 80%; the middle value sits exactly at the limit.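

Compound 4 gives > 300000 nM in this assay, again a limit, so its steps from compound 1, compound 2 and compound 3 cannot be read in size. The compounds shown leave open where any of them reaches a half-maximal cytotoxic concentration, and whether the aryl substitution affects it.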